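A few compounds are considered here, and "the series" means these few. Any claim that something is new, unique, unknown or untested is made for them only; others in the source may bear on it.

Measured so far in a functional assay on CCRF-CEM cells (Homo sapiens) for inhibition, with a stated time of 72 h; a lower number here means a stronger inhibitor, a higher number a weaker inhibitor:
compound 1 `CN(Cc1ccccc1)Cc1ncnc2c1ncn2[C@@H]1O[C@H](CO)[C@@H](O)[C@H]1O`: 20300 nM
compound 2 `OC[C@H]1O[C@@H](n2cnc3c(CSCc4ccccc4)ncnc32)[C@H](O)[C@@H]1O`: 9200 nM

Compound 1 gives the highest of the two numbers in this assay; compound 2 sits nearest, and the step of a 2.2-fold lower number from compound 1 to compound 2 (0.34 log units; beyond the scatter) is a modest one. Compound 3 `CSCc1ncnc2c1ncn2[C@@H]1O[C@H](CO)[C@@H](O)[C@H]1O` is not yet measured. It differs from compound 1 as follows: methylsulfanyl in place of benzyl(methyl)amino on a saturated chain carbon bound to an aromatic carbon. For the measured compounds named here, the only step that bears on it is a 2.2-fold lower number from compound 1 to compound 2 (0.34 log units; beyond the scatter), which also replaced the benzyl(methyl)amino group by a sulfur-linked group at this position. Because of a 2.2-fold lower number from compound 1 to compound 2 (0.34 log units; beyond the scatter) a modest lowering is expected, with added uncertainty since the benzyl group leaves as well. A step of a 1.7-fold lower number from compound 1 to compound 3 (0.23 log units; within the scatter) is therefore expected. Compound 3 is estimated at 12000 nM, within 4000 nM to 40000 nM.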

Compound 3, half-maximal inhibitory concentration: 15000 nM
Beside the measured number, compound 3's estimate is 1.3-fold (0.10 log units) below it; measured number inside the range.
By their numbers in this assay, from the lowest: compounds 2, 3 and 1 (each within the scatter of the next, the first and the last beyond it).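

In this assay the phenyl ring can leave the group on this saturated chain carbon with no change that can be read: removing it shows a 1.6-fold higher number from compound 2 to compound 3 (0.21 log units; within the scatter) and exchanging the whole benzyl(methyl)amino group for methylsulfanyl shows a 1.4-fold lower number from compound 1 to compound 3 (0.13 log units; within the scatter). Among these compounds, activity at this position therefore does not depend on the phenyl ring. No measurement at hand accounts for these numbers. Open, going by these compounds, is how this assay responds to a primary amine, a carboxylic acid or a longer alkyl chain on this carbon. On these data alone, whether any group here can move the number far from this narrow range also stays open.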